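The compounds below may be only part of what the source reports. "The series", "measured", "known", "first", "only" and "open" are said of these compounds alone.

Of the compounds shown here, three that share one core have been tested in a functional assay on OVCAR-3 cells (Homo sapiens) for cytotoxicity, read by sulforhodamine B assay, with a stated time of 48 h, tested at 10 uM; on this read-out higher numbers stand for a weaker effect at the one concentration tested and lower numbers for a stronger effect. Compound 1 `COc1cc(-c2cc(/C=C/C(=O)c3ccc(N)cc3)[nH]n2)cc(OC)c1OC` gives -71% in this assay, the highest of the three numbers, so its effect is the weakest shown. Compound 2 `COc1ccc(-c2cc(/C=C/C(=O)c3ccc(OC)c(OC)c3)[nH]n2)cc1` gives -95% in this assay, and compound 3 `COc1ccc(-c2cc(/C=C/C(=O)c3cc(OC)c(OC)c(OC)c3)[nH]n2)cc1OC` gives -85%; both lie beyond the scatter from compound 1. Compound 4 `COc1ccc(C(=O)/C=C/c2cc(-c3cc(OC)c(OC)c(OC)c3)n[nH]2)cc1OC` differs from compound 1 in one place: 3,4-dimethoxyphenyl in place of 4-aminophenyl on a carbonyl carbon. Compound 2 and compound 3, which carry no 4-aminophenyl, show the lower numbers, so the change is expected to move compound 4 downward, toward a stronger effect, by more than the scatter, and the expected step is a number 14 percentage points lower from compound 1 to compound 4 (beyond the scatter). For compound 4 the estimate is -85%, with a range from -100% to -65%.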

Compound 4, a percentage reported as activity, at one concentration (the size of the read-out at that concentration, not a potency): -91%
The estimate for compound 4 lay 6 percentage points above the measured number; low and high end bracket the measured number.
By their numbers in this assay, from the lowest: compounds 2, 4 and 3 (each within the scatter of the next); then compound 1.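

In this assay, for the compounds shown here, 3,4-dimethoxyphenyl in place of 4-aminophenyl on a carbonyl carbon gives a number 20 percentage points lower from compound 1 to compound 4 (beyond the scatter) and so provides the first reading of a single change at this position. With the rest of the structure held fixed, this swap goes with a stronger effect, beyond the usual scatter. Nothing available explains why the step occurs.

Open, going by these compounds, is how a plain phenyl or a 4-hydroxyphenyl on that carbonyl carbon would read. Until then, the step cannot be divided between the loss of the amino group and the arrival of the two methoxy groups.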